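The source may hold more compounds than are shown below. What is called first, only, known or untested is meant among the compounds shown, and "the series" means these compounds.

Of the compounds shown here, three have numbers so far in an ADME assay for permeability, using PAMPA, at pH 7.4; on this read-out lower numbers stand for lower permeability and higher numbers for higher permeability: compound 1 (`Cc1cccc(S(=O)(=O)Nc2ccc(-c3cccc(Cl)c3)nn2)c1`) gives 40.2 10^-6 cm/s, compound 2 (`CN(C)c1ccccc1S(=O)(=O)Nc1ccc(-c2cccc(Cl)c2)nn1`) gives 35.7 10^-6 cm/s, and compound 3 (`Cc1ccc(S(=O)(=O)Nc2ccc(-c3ccccc3N(C)C)nn2)cc1`) gives 35.7 10^-6 cm/s. Compound 3 therefore lies within the scatter of both other compounds, and these three numbers support no ranking. Among the measured compounds shown here, no two of the measured compounds differ in one place only, so no measured single-change step is available as a guide.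

The next compound is compound 4 (`Cc1ccc(S(=O)(=O)Nc2ccc(-c3ccccc3N3CCCCC3)nn2)cc1`), which carries piperidin-1-yl in place of dimethylamino on an aromatic carbon, ortho to a large group: piperidin-1-yl in place of dimethylamino on an aromatic carbon. The expectation rests on compound 3 at 35.7 10^-6 cm/s and on the closeness of the three measured numbers. In this assay, no change beyond the scatter is expected, and neither direction is favoured. The estimated step is a 1.0-fold higher number from compound 3 to compound 4 (0.00 log units; within the scatter). The expected value for compound 4 is 36 10^-6 cm/s, within an estimated range of 18 10^-6 cm/s to 68 10^-6 cm/s.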

Compound 4, apparent permeability: 50.6 10^-6 cm/s
Compound 4: middle estimate off by 1.4-fold (0.15 log units), on the low side, and the stated range covers the measured number.
By their numbers in this assay, from the lowest: compounds 2, 3, 1 and 4 (each within the scatter of the next).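

In this assay the series now has its first single-change step: piperidin-1-yl in place of dimethylamino on an aromatic carbon, ortho to a large group, gives a 1.4-fold higher number from compound 3 to compound 4 (0.15 log units; within the scatter) and so offers no resolved difference between the two groups. At this position, the read-out therefore tolerates a six-membered non-aromatic ring in place of the open dimethylamino group, at least for this one pair, with the hydrogen-bond donor and acceptor counts unchanged. No measurement at hand offers an explanation for the size of this step.

As far as these compounds go, whether a morpholin-4-yl group, a primary amine or a carboxylic acid at this position would stay within the scatter remains open. One step also cannot show whether this change would read the same on the other substitution patterns seen in compound 1 and compound 2.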